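A few compounds are considered here, and "the series" means these few. Any claim that something is new, unique, unknown or untested is made for them only; others in the source may bear on it.

In a functional assay on RT-112 cells (Homo sapiens) for antiproliferative activity, read by MTT assay, with a stated time of 72 h (on this read-out lower numbers stand for stronger inhibition of growth and higher numbers for weaker inhibition of growth), compound 1 (`COc1cc(Nc2ncnc3c(NC(=O)Nc4ccc(C)cc4C)cccc23)cc(OC)c1`) gives 1290 nM. Compound 2 (`COc1cc(Nc2ncnc3c(NC(=O)c4ccc(N5CCN(C)CC5)cc4)cccc23)cc(OC)c1`) gives 14200 nM, the higher of the two numbers and therefore the weaker inhibition of growth, and the gap between them lies beyond the usual scatter. The two compounds do not form a pair that differs in one place, so their gap says little about a single exchange.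

The next compound to be tested, compound 3 (`COc1cc(Nc2ncnc3c(NC(=O)c4ccc(CN(C)C)cc4)cccc23)cc(OC)c1`), keeps the core and amide link of compound 2. It carries (dimethylamino)methyl in place of 4-methylpiperazin-1-yl on an aromatic carbon, para to a large group: (dimethylamino)methyl in place of 4-methylpiperazin-1-yl on an aromatic carbon.

Going by the values given here, no measured pair shows what such an exchange does in this assay, so neither direction has support from the data. The working expectation is therefore a small step at most, staying close to the value of compound 2 at 14200 nM. The expected change is a 1.6-fold lower number from compound 2 to compound 3 (0.20 log units; within the scatter), which would be no change beyond the scatter. For compound 3 the estimated value is 9000 nM, with an expected range from 3000 nM to 25000 nM.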

Compound 3, concentration for 50% growth inhibition: 4370 nM
Beside the measured number, compound 3's estimate is 2.1-fold (0.31 log units) above it; the measured number falls inside the stated range.
By their numbers in this assay, from the lowest: compound 1; then compound 3; then compound 2.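

In this assay, going by these compounds alone, the exchange of 4-methylpiperazin-1-yl for (dimethylamino)methyl on an aromatic carbon, para to a large group, gives a 3.2-fold lower number from compound 2 to compound 3 (0.51 log units; beyond the scatter), the first reading of a change in one place, and it moves towards stronger inhibition of growth. In this single pair the entering group has fewer heavy atoms and no ring, so the six-membered ring of compound 2 is not required for growth inhibition at this level. Even so, the change on the carbonyl carbon, 4-((dimethylamino)methyl)phenyl in place of (2,4-dimethylphenyl)amino, gives a 3.4-fold higher number from compound 1 to compound 3 (0.53 log units; beyond the scatter), so compound 3 does not reach compound 1, and nothing measured here accounts for either step.

As far as these compounds go, it remains open whether a primary amine such as aminomethyl, a morpholin-4-yl ring or a longer chain such as 2-(dimethylamino)ethyl at the same place would continue this trend or reverse it. From the compounds shown here alone, it is also open whether a basic amine chain of this kind would change the number at all when attached to the (2,4-dimethylphenyl)amino side of compound 1.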